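Swapping Amino for Hydroxy: Expected Effect on Cytotoxicity

This account rests on a few compounds, and the source may have more. Where it says the series, first, only, none or still open, it means among the compounds named here.

Three compounds sharing one core were tested in an ADME assay on U2OS cells (Homo sapiens) for cytotoxicity, with a stated time of 48 h; on this read-out lower numbers stand for higher toxicity in this test and higher numbers for lower toxicity in this test. Compound 1 `Cc1ccc(Nc2nc(NCC3CCCO3)nc(Nc3ccc(C)cc3)n2)cc1` gave > 50000 nM; > 50000 nM; > 50000 nM; > 50000 nM (4 entries) in this assay. Compound 2 `COc1ccc(Nc2nc(Nc3ccc(OC)cc3)nc(NC3CCCC3)n2)cc1` likewise gave only a limit, > 50000 nM. Within the data shown here, compound 3 `Cc1ccc(Nc2nc(N)nc(Nc3ccc(C)cc3)n2)cc1` is the only compound with an actual number, giving 42200 nM in this assay. Its number sits just under (the limit of > 50000 nM in this assay, at which 1 of the 3 values shown sits). Compound 4 `Cc1ccc(Nc2nc(O)nc(Nc3ccc(C)cc3)n2)cc1` differs from compound 3 by hydroxy in place of amino on an aromatic carbon. Among the measured compounds shown here, no measured pair shows the effect of such a change, so no step beyond the usual scatter is expected. The estimate for compound 4 in this assay is 45000 nM, within 20000 nM to 100000 nM. This expected value amounts to a step of a 1.1-fold higher number from compound 3 to compound 4 (0.03 log units; within the scatter).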

Compound 4, half-maximal cytotoxic concentration: > 12500 nM
Compound 4: a limit, no number (the forecaster's own chance of this, stated with the estimate: 50%); the middle value is on the limit's open side.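

In this assay, among these compounds, compound 4 gives only a limit, > 12500 nM, and no step from compound 3 to compound 4 can be read. From the compounds shown here alone, whether hydroxy in place of amino shifts this read-out stays open.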